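The source may report more compounds than this note shows. Statements on the series, on what has been measured and on what is new or still open speak of the compounds shown alone.

In a functional assay on A549 cells (Homo sapiens) for antiproliferative activity, read by spectrophotometry, with a stated time of 2 days (a lower number here means a stronger inhibitor of growth, a higher number a weaker inhibitor of growth), compound 1 `COc1cc(Nc2ncc(C(F)(F)F)c(N3Cc4cccc(N(C)S(C)(=O)=O)c4C3)n2)cc(OC)c1` gives 24800 nM and compound 2 `Cc1cc(Cl)ccc1Nc1ncc(C(F)(F)F)c(N2Cc3cccc(N(C)S(C)(=O)=O)c3C2)n1` gives 25500 nM, so the two stand level within the scatter. Compound 3 `COc1cc(Nc2ncc(C(F)(F)F)c(N3Cc4cccc(N(C)S(C)(=O)=O)c4C3)n2)cc(C(F)(F)F)c1` keeps the core of compound 2 and carries 3-methoxy-5-(trifluoromethyl)phenyl in place of 4-chloro-2-methylphenyl on a nitrogen on an aromatic ring. Within the data shown here, only one measured step bears on this change, a 1.0-fold higher number from compound 1 to compound 2 (0.01 log units; within the scatter), which swapped the group at this same place and stayed within the scatter. One step is thin evidence, and the group entering here has not been measured on this core. Even so, no step beyond the scatter is expected in this assay, in either direction. The estimated change is a 1.2-fold lower number from compound 2 to compound 3 (0.06 log units; within the scatter). For compound 3 the expected value is 22000 nM, with an estimated range from 10000 nM to 45000 nM.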

Compound 3, concentration for 50% growth inhibition: > 30000 nM
Compound 3 gave a limit, no number (the forecaster's own chance of this, stated with the estimate: 10%); middle value at least 1.3-fold (0.13 log units) from the limit.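

Compound 3 gives no number in this assay, only a limit of the assay: the limit of > 30000 nM in this assay, at which 1 of the 3 values shown sits. Read as floors, the two steps are an at least 1.1-fold higher number from compound 2 to compound 3 (0.07 log units; that floor lies within the scatter) and an at least 1.2-fold higher number from compound 1 to compound 3 (0.08 log units; that floor lies within the scatter), so neither proves a real change and neither rules one out. What is new is that the place on the nitrogen now holds a third substituted phenyl, and that a smaller edit than the earlier swap, one methoxy replaced by trifluoromethyl, also brings no stronger inhibition of growth.

As far as these compounds go, how far the true value of compound 3 lies past its limit stays open. Also open is whether a phenyl carrying an amine or a carboxylic acid at this place would give a much lower number than the three substituted phenyls shown here.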